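Replacing the Dimethylphenoxy Group: Expected Effect on Cell Tolerance

The source may hold more compounds than are shown below. What is called first, only, known or untested is meant among the compounds shown, and "the series" means these compounds.

Three compounds sharing one core have been examined in an ADME assay on MT4 cells (Homo sapiens) for cytotoxicity, read by MTT assay, with a stated time of 4 days; a higher number here means that more compound is tolerated, a lower number that less compound is tolerated. Compound 1 `COc1cc(C#N)cc(OC)c1Oc1nc(Nc2ccc(C#N)cc2)nc2ccccc12` gives 194000 nM. Compound 3 `COc1cc(C#N)cc(Cl)c1Oc1nc(Nc2ccc(C#N)cc2)nc2ccccc12` differs from compound 1 only by chloro in place of methoxy on an aromatic carbon. In this assay compound 3 gives 220000 nM, and the step of a 1.1-fold higher number from compound 1 to compound 3 (0.05 log units; within the scatter) shows that this exchange made no difference beyond the usual scatter. Compound 2 `Cc1cccc(C)c1Oc1nc(Nc2ccc(C#N)cc2)nc2ccccc12` gives 35000 nM, the lowest of the three numbers, meaning that cells tolerate it least; it stands beyond the scatter below both compound 1 and compound 3.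

Compound 4 `N#Cc1ccc(Nc2nc(Oc3ccc(F)cc3)c3ccccc3n2)cc1` has not yet been measured. It differs from compound 2 by 4-fluorophenyl in place of 2,6-dimethylphenyl on an oxygen on an aromatic ring. Going by the values given here, no measured step touches this particular exchange: the only measured step, from compound 1 to compound 3, concerns a substituent on a differently decorated ring and lay within the scatter. The values of compound 1 and compound 3 show that other groups on that oxygen are tolerated far better than the 2,6-dimethylphenyl of compound 2, which hints that compound 4 could move upward, but there is no direct evidence for the 4-fluorophenyl group. The estimate for compound 4 in this assay is therefore 60000 nM, with a range from 20000 nM to 200000 nM, which is expected to amount to a step of a 1.7-fold higher number from compound 2 to compound 4 (0.23 log units; within the scatter).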

Compound 4, half-maximal cytotoxic concentration: > 351000 nM
Compound 4: a limit, no number; the forecaster's own chance of this, stated with the estimate: 10%; middle value at least 5.8-fold (0.76 log units) from the limit.
By their numbers in this assay, from the lowest: compound 2; then compounds 1 and 3 (each within the scatter of the next). At a limit, above all of these: compound 4.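

Compound 2 to compound 4 is the first single-place change shown at the group on this oxygen, and in this assay it gives an at least 10-fold higher number from compound 2 to compound 4 (1.00 log units; beyond the scatter). Going by these compounds alone, the only earlier step, a swap of methoxy for chloro on a differently decorated ring, stayed within the scatter, so this is the first direct sign that exchanging the whole aryl group on this oxygen can shift cell tolerance. Compound 4 gives a limit of the assay, not a number: the limit of > 351000 nM in this assay, at which 1 of the 4 values shown sits.

On these data alone, how far tolerance rises for compound 4 stays unknown, and the result does not show whether losing the two methyl groups or gaining the fluorine matters more. A plain phenyl or a 4-methoxyphenyl on the same oxygen would be needed to separate these, and a cyclohexyl group there remains an open case.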